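The source may report more compounds than this note shows. Statements on the series, on what has been measured and on what is new or still open speak of the compounds shown alone.

a functional assay for agonist activity at G protein-coupled receptor 88 (Homo sapiens), read by HTRF and cAMP accumulation (on this read-out lower numbers stand for an effect already at smaller amounts and higher numbers for an effect only at larger amounts of compound), is the measure used throughout. Compound 1 `CC[C@H](C)[C@H](N)CN(C(=O)[C@@H]1C[C@H]1c1cccc(F)c1)c1ccc(-c2ccccc2)cc1` gives 560 nM in this assay. Compound 2 `CC(C)C[C@H](N)CN(C(=O)[C@@H]1C[C@H]1c1ccccc1)c1ccc(-c2ccncc2)cc1` gives 13000 nM in this assay, the highest of the two numbers; compound 1 stands nearest, with a far lower number, and the gap between these two values lies beyond the usual scatter. Compound 3 `Cc1ccccc1-c1ccc(N(C[C@@H](N)CC(C)C)C(=O)[C@@H]2C[C@H]2c2ccccc2)cc1` has not yet been measured. It differs from compound 2 in one place: 2-methylphenyl in place of pyridin-4-yl on an aromatic carbon. Among the measured compounds shown here, no pair of measured compounds shows this exact change on its own, so the expectation leans on a comparison. Compound 1 gives 560 nM with a six-membered aromatic ring of carbon only in the same place. On that basis a clear drop is expected, estimated at an 8.7-fold lower number from compound 2 to compound 3 (0.94 log units; beyond the scatter). For compound 3 the estimated value in this assay is 1500 nM, within a range from 400 nM to 6000 nM.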

Compound 3, half-maximal effective concentration: 3400 nM
Compound 3: middle estimate off by 2.3-fold (0.36 log units), on the low side, within the range that was stated.
By their numbers in this assay, from the lowest: compound 1; then compound 3; then compound 2.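

In this assay, among the compounds shown here, the direct exchange of pyridin-4-yl for 2-methylphenyl gives a 3.8-fold lower number from compound 2 to compound 3 (0.58 log units; beyond the scatter), a first reading of a change at this position with the rest of the molecule held constant. The step shows that a ring nitrogen at this position is not required for activity, since the ring of carbon only in compound 3 still gives an effect at smaller amounts of compound. The exchange removes the ring nitrogen and adds a methyl group at once, so this single step cannot assign the difference to either alteration, and no measurement here explains it.

The same core carrying a plain phenyl group would be needed to separate those two alterations. From the compounds shown here alone, whether a non-aromatic ring such as cyclohexyl could also occupy this position remains open.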